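Adding a Methoxy Group to Compound 2

This account rests on a few compounds, and the source may have more. Where it says the series, first, only, none or still open, it means among the compounds named here.

Of the compounds shown here, three have been measured in an assay on BTI cells for inhibition of Amine oxidase [flavin-containing] B (Homo sapiens), read by fluorescence, with a stated time of 20 min, tested at 1 uM; a higher number here means more inhibition at the concentration tested (going by the name of the read-out), a lower number less inhibition. Compound 1 `COc1cccc2c1OCC(C)(C)C2N` gives 4.3%. Compound 2 `CC1(C)COc2ccccc2C1O` gives 8%, and compound 3 `C#CCN(Cc1ccccc1)C1c2cccc(OC)c2OCC1(C)C` gives 14.7%. On these numbers compound 2 stands second highest of the three; the nearest is compound 1, whose value differs by an amount within the usual scatter, and the furthest is compound 3, whose value also lies within the scatter of compound 2. None of the three separates from the others, and all sit in a low range of inhibition at the single concentration tested.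

Compound 4 `COc1cccc2c1C(O)C(C)(C)CO2` is not yet measured. It differs from compound 2 in one place: methoxy in place of hydrogen on an aromatic carbon. For the measured compounds named here, compound 1 carries the same methoxy group on its core and gives 4.3%, a number within the scatter of the value of compound 2, so this group has not set a compound apart in the numbers so far. Going by the values given here, no step between measured compounds covers this change directly. In this assay the expected step is no change at the digits printed from compound 2 to compound 4 (within the scatter), none beyond the scatter in either direction. Compound 4 is therefore estimated to give 8%, with a range from 0% to 18%.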

Compound 4, a percentage reported as inhibition, at one concentration (the size of the read-out at that concentration, not a potency): 5.3%
Compound 4: the middle estimate sits 2.7 percentage points above what was measured; measured number inside the range.
By their numbers in this assay, from the lowest: compounds 1, 4, 2 and 3 (each within the scatter of the next, the first and the last beyond it).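

In this assay, methoxy in place of hydrogen on an aromatic carbon can now be read directly. For the compounds shown here, none of the earlier compounds formed a pair differing in this one place. The step is a number 2.7 percentage points lower from compound 2 to compound 4 (within the scatter), so at this carbon of the six-membered aromatic ring, ortho to a fused ring and meta to a fused ring, methoxy does not separate the two compounds at the single concentration tested. No measurement shown bears on why the step takes this size.

The compounds shown leave open whether another group on this aromatic carbon, such as an amine, a hydroxyl or a longer ether chain, would give a step beyond the scatter. They also leave open whether methoxy would read the same way on a compound with higher inhibition, as all of these numbers lie low in the range and a step this small from a low starting value says little about how the same change behaves elsewhere.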